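Swapping the Aryl Group in a Fused Sulfone Series

The source may report more compounds than this note shows. Statements on the series, on what has been measured and on what is new or still open speak of the compounds shown alone.

In an ADME assay on microsomes from liver (Homo sapiens) for metabolic stability, tested at 2.5 uM (on this read-out higher numbers stand for fast clearance and lower numbers for slow clearance), compound 1 `O=S(=O)(c1cc(F)cc(F)c1)c1cnc2c(F)cccc2c1-c1cccc(Cl)c1` gives 0.64 mL/min. Within the data shown here, compound 2 `Cc1ccc(S(=O)(=O)c2cnc3c(F)cccc3c2-c2ccc(F)cc2)cc1F` gives 2.75 mL/min in this assay, the highest of the two numbers so far, with compound 1 lying below it by a gap that exceeds the usual scatter. Compound 3 `Cc1ccc(S(=O)(=O)c2cnc3c(F)cccc3c2-c2cccc(Cl)c2)cc1F` has not yet been measured; it differs from compound 2 in a single place: 3-chlorophenyl in place of 4-fluorophenyl on an aromatic carbon. Among the measured compounds shown here, compound 1 shares the 3-chlorophenyl of compound 3 but carries a different sulfone arm, so no single-point step links the two measured compounds. The writer expects compound 3 to show a modest downward step a 1.4-fold lower number from compound 2 to compound 3 (0.14 log units; within the scatter) in this assay, probably not much beyond the scatter, as the two measured compounds differ in more than one place. Compound 3 is therefore estimated at 2 mL/min in this assay, within a range of 0.8 mL/min to 4.5 mL/min.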

Compound 3, intrinsic clearance in a liver preparation (reported as CLH), per the amount of preparation that the assay uses: 3.18 mL/min
Beside the measured number, compound 3's estimate is 1.6-fold (0.20 log units) below it; measured number inside the range.
By their numbers in this assay, from the lowest: compound 1; then compounds 2 and 3 (each within the scatter of the next).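

In this assay, 3-chlorophenyl in place of 4-fluorophenyl on the aromatic carbon gives a 1.2-fold higher number from compound 2 to compound 3 (0.06 log units; within the scatter), so with the 3-fluoro-4-methylphenyl arm on the sulfonyl sulfur, the two aryl groups cannot be told apart at this position. Among these compounds, with 3-chlorophenyl held constant, 3-fluoro-4-methylphenyl in place of 3,5-difluorophenyl on the sulfonyl sulfur gives a 5.0-fold higher number from compound 1 to compound 3 (0.70 log units; beyond the scatter), and this is the only single-place change here that lies beyond the scatter. Nothing available explains either step.

Going by these compounds, whether 4-fluorophenyl and 3-chlorophenyl would also read alike with the 3,5-difluorophenyl arm remains open. Also open, on these data alone, is how this assay would respond to a pyridyl group or a morpholine on the aromatic carbon, or to a methoxy group in place of the methyl on the sulfone arm.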